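The source may report more compounds than this note shows. Statements on the series, on what has been measured and on what is new or still open speak of the compounds shown alone.

In an assay on nucleic acid for inhibition of Nucleic Acid, read by fluorescence, tested at 100 uM (on this read-out higher numbers stand for more inhibition at the one concentration tested (going by the name of the read-out) and lower numbers for less inhibition), compound 2 `CCCCC(O)Cn1cc(CN(CCCC)CCCC)nn1` gives 18%, while compound 1 `CCCCN(CCCC)Cc1cn(CC(O)COCc2ccccc2)nn1` gives 6%. The change between them is benzyloxy in place of propyl on a saturated chain carbon, two bonds along the chain from an oxygen on a saturated carbon, and it made a step of a number 12 percentage points lower from compound 2 to compound 1 (beyond the scatter). Compound 3 `CCCCC(O)Cn1cc(CN2CCCC(C(=O)OCC)C2)nn1` gives 53% in this assay, the highest of the three numbers; the difference between the core of compound 3 and the core of compound 2 is not broken down here. Compound 4 `CCOC(=O)C1CCCN(Cc2cn(CC(O)COCc3ccccc3)nn2)C1` has not yet been measured and differs from compound 3 by benzyloxy in place of propyl on a saturated chain carbon, two bonds along the chain from an oxygen on a saturated carbon; as the place is described in the same words, this is the same change as that between compound 2 and compound 1. Because that change gave a number 12 percentage points lower from compound 2 to compound 1 (beyond the scatter), a step of a number 15 percentage points lower from compound 3 to compound 4 (beyond the scatter) is expected here. Compound 4 is therefore estimated at 38% in this assay, most likely between 20% and 55%.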

Compound 4, a percentage reported as inhibition, at one concentration (the size of the read-out at that concentration, not a potency): 26%
Compound 4: middle estimate off by 12 percentage points, on the high side; the measured number falls inside the stated range.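

In this assay, benzyloxy in place of propyl on the second core gave a number 27 percentage points lower from compound 3 to compound 4 (beyond the scatter). The direction of the change carried over from one core to the other, but its size did not: the same change on two cores in this assay, a number 12 percentage points lower (beyond the scatter) from compound 2 to compound 1 and a number 27 percentage points lower (beyond the scatter) from compound 3 to compound 4, 15 percentage points apart, beyond the scatter of two such steps
This shows that, across these two pairs, the change lowers the number by an amount that depends on the core, but two pairs establish no rule for the series and do not show what sets the size of the step.

The compounds shown leave open how other groups at the same place would read, such as an amine, a carboxylic acid or a longer chain. They also leave open whether the change would lower the number on a third core.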